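A few compounds are considered here, and "the series" means these few. Any claim that something is new, unique, unknown or untested is made for them only; others in the source may bear on it.

Measured in a functional assay on HOP-62 cells (Homo sapiens) for inhibition, read by sulforhodamine B assay; on this read-out higher numbers stand for weaker inhibition of growth and lower numbers for stronger inhibition of growth:
compound 1 `c1ccc(-c2ccc(-c3ccc(-c4nc5ccccc5[nH]4)cc3)cc2)cc1`: 100000 nM
compound 2 `Cc1ccc2[nH]c(-c3ccc(-c4ccc(-c5cccc(Cl)c5)cc4)cc3)nc2c1`: 2740 nM
compound 3 `COc1ccc(-c2ccc(-c3ccc(-c4nc5cc(C)ccc5[nH]4)cc3)cc2)cc1OC`: 2120 nM

Compound 3 stands level with compound 2 within the scatter, and both lie far under compound 1. Next is compound 4 `Cc1ccc2[nH]c(-c3ccc(-c4ccc(-c5ccccc5)cc4)cc3)nc2c1`, with phenyl in place of 3,4-dimethoxyphenyl on an aromatic carbon. For the measured compounds named here, the only measured step at this place is a 1.3-fold lower number from compound 2 to compound 3 (0.11 log units; within the scatter). Going by the values given here, no measured compound pairs the core of compound 4 with phenyl. Compound 1 carries phenyl at this place but has a different core, and compound 1 gives 100000 nM. A modest rise in this assay is therefore expected, with a 2.8-fold higher number from compound 3 to compound 4 (0.45 log units; beyond the scatter) as the estimated step. The estimate for compound 4 is 6000 nM, with an expected range of 1500 nM to 40000 nM.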

Compound 4, concentration for 50% growth inhibition: 39300 nM
Compound 4: middle estimate off by 6.6-fold (0.82 log units), on the low side, within the range that was stated.
By their numbers in this assay, from the lowest: compounds 3 and 2 (each within the scatter of the next); then compound 4; then compound 1.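

In this assay the bare phenyl at this position is clearly set apart from both substituted rings, with a 19-fold higher number from compound 3 to compound 4 (1.27 log units; beyond the scatter) and a 14-fold higher number from compound 2 to compound 4 (1.16 log units; beyond the scatter) as large steps, although the 3,4-dimethoxyphenyl and 3-chlorophenyl compounds stand level within the scatter. Methyl in place of hydrogen on an aromatic carbon of the core gives a smaller, modest step, with a 2.5-fold lower number from compound 1 to compound 4 (0.41 log units; beyond the scatter) as its size. No supporting data are available to account for these steps.

As far as these compounds go, it remains open whether a single methoxy group on the phenyl would be enough to match compound 3. An amine or a carboxylic acid at this position also remains untested in the compounds shown here.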